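The source may report more compounds than this note shows. Statements on the series, on what has been measured and on what is new or still open speak of the compounds shown alone.

Working notes. In a functional assay on PC-3 cells (Homo sapiens) for antiproliferative activity, read by MTT assay, tested at 1 uM (a higher number here means a stronger effect of the compound at the concentration tested, a lower number a weaker effect), compound 1 `COc1ccc(C2OC(c3cc(OC)c(OC)c(OC)c3)=NN2C(C)=O)c(OC)c1` gives 69.5%, compound 2 `COc1cc(C2=NN(C(C)=O)C(c3ccc(F)c(F)c3)O2)cc(OC)c1OC` gives 35.5% and compound 3 `COc1cc(C2=NN(C(C)=O)C(c3ccc(F)cc3)O2)cc(OC)c1OC` gives 0%; compound 3 is the lowest of the three, its nearest neighbour being compound 2. Compound 4 `COc1cc(C2=NN(C(C)=O)C(c3cc(Cl)cc(Cl)c3)O2)cc(OC)c1OC` differs from compound 3 by 3,5-dichlorophenyl in place of 4-fluorophenyl on a saturated ring carbon. The steps on the same saturated ring carbon were large: a number 69.5 percentage points lower from compound 1 to compound 3 (beyond the scatter) and a number 35.5 percentage points lower from compound 2 to compound 3 (beyond the scatter), the latter showing that removing a second halogen from the ring drops the read-out. Compound 4 carries two halogens again, so a step back up, roughly the size of the step from compound 2 to compound 3, is expected: a number 30 percentage points higher from compound 3 to compound 4 (beyond the scatter). For compound 4 the expected value is 30%, range 5% to 60%.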

Compound 4, a percentage reported as inhibition, at one concentration (the size of the read-out at that concentration, not a potency): 52.7%
Compound 4: middle estimate off by 22.7 percentage points, on the low side, and the stated range covers the measured number.
By their numbers in this assay, from the lowest: compound 3; then compound 2; then compound 4; then compound 1.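

At this saturated ring carbon in this assay, 3,5-dichlorophenyl lifts the read-out well clear of 4-fluorophenyl, a number 52.7 percentage points higher from compound 3 to compound 4 (beyond the scatter), and also exceeds 3,4-difluorophenyl, a number 17.2 percentage points higher from compound 2 to compound 4 (beyond the scatter), so the two dihalogenated aryl groups are not interchangeable. It still falls short of 2,4-dimethoxyphenyl, a number 16.8 percentage points lower from compound 1 to compound 4 (beyond the scatter). No measured evidence accounts for these steps. Halogen identity and halogen placement change together between compound 2 and compound 4, so their separate contributions remain unresolved. As far as these compounds go, how an aryl group bearing an amine or a carboxylic acid would read at this carbon also remains open.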